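The compounds below may be only part of what the source reports. "The series", "measured", "known", "first", "only" and "open" are said of these compounds alone.

Measured compounds, antiproliferative read-out in a functional assay on HepG2 cells (Homo sapiens) for antiproliferative activity, read by MTT assay, with a stated time of 72 h; on this read-out higher numbers stand for weaker inhibition and lower numbers for stronger inhibition:

compound 1 `COc1cc2c(Nc3ccc(C#N)cc3)ncnc2cc1OCCCN1CCC(C)CC1` gives 32100 nM
compound 2 `COc1cc2c(Nc3ccc(C#N)cc3)ncnc2cc1OCCCN1CCN(C)CC1` gives 13800 nM
compound 3 `COc1cc2c(Nc3ccccc3C#N)ncnc2cc1OCCCN1CCC(C)CC1` gives 4030 nM

Two single-point changes are seen among these three. Going by the values given here, the first is the exchange of the basic ring at the end of the propyl chain, (4-methylpiperazin-1-yl in place of 4-methylpiperidin-1-yl on a saturated chain carbon, three bonds along the chain from an oxygen on an aromatic ring). This step reads a 2.3-fold lower number from compound 1 to compound 2 (0.37 log units; beyond the scatter). The second is the move of the nitrile on the aniline ring, (2-cyanophenyl in place of 4-cyanophenyl on a nitrogen on an aromatic ring); here the two compounds hold the same atoms joined differently, and the step reads an 8.0-fold lower number from compound 1 to compound 3 (0.90 log units; beyond the scatter). Compound 3 stands lowest of the three numbers, beyond the scatter from both others.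

Compound 4 `COc1cc2c(Nc3ccccc3C#N)ncnc2cc1OCCCN1CCN(C)CC1` is not yet measured. It differs from compound 3 by 4-methylpiperazin-1-yl in place of 4-methylpiperidin-1-yl on a saturated chain carbon, three bonds along the chain from an oxygen on an aromatic ring. Among the compounds with values here, this is the same change already made from compound 1 to compound 2, at the same place on the chain, so the pair compound 1 to compound 2 is the only measured guide for it. The cores of the two pairs differ as told by 2-cyanophenyl in place of 4-cyanophenyl on a nitrogen on an aromatic ring.

With one prior instance only, a step of similar size is expected, a 2.2-fold lower number from compound 3 to compound 4 (0.35 log units; beyond the scatter), resting on compound 1 to compound 2 showing a 2.3-fold lower number from compound 1 to compound 2 (0.37 log units; beyond the scatter) and on compound 3 giving 4030 nM. Compound 4 is therefore estimated at 1800 nM in this assay, with a range of 700 nM to 4500 nM to allow for the scatter and for the change of core.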

Compound 4, half-maximal inhibitory concentration: 26400 nM
Compound 4: middle estimate off by 15-fold (1.17 log units), on the low side; the measured number lies above the stated range.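

In this assay, the exchange of 4-methylpiperidin-1-yl for 4-methylpiperazin-1-yl does not carry from one core to the other, since the step now reads a 6.6-fold higher number from compound 3 to compound 4 (0.82 log units; beyond the scatter), opposite in direction to the earlier step: the same change on two cores in this assay, a 2.3-fold lower number (0.37 log units; beyond the scatter) from compound 1 to compound 2 and a 6.6-fold higher number (0.82 log units; beyond the scatter) from compound 3 to compound 4, 15-fold (1.18 log units) apart, beyond the scatter of two such steps. The move of the nitrile does not carry over either, reading a 1.9-fold higher number from compound 2 to compound 4 (0.28 log units; within the scatter) with 4-methylpiperazin-1-yl on the chain, so no order can be given for that pair, unlike the earlier step with 4-methylpiperidin-1-yl: the same change on two cores in this assay, an 8.0-fold lower number (0.90 log units; beyond the scatter) from compound 1 to compound 3 and a 1.9-fold higher number (0.28 log units; within the scatter) from compound 2 to compound 4, 15-fold (1.18 log units) apart, beyond the scatter of two such steps. The two changes are therefore not independent across these four compounds, and the lowest number, that of compound 3, belongs to the combination of 2-cyanophenyl with 4-methylpiperidin-1-yl, but four compounds in a single cell assay do not show why the steps differ or whether this dependence extends to other members of the series.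

Going by these compounds, it remains open whether the dependence persists with a morpholine or a dimethylamino group at the end of the chain, or with a shorter ethyl or longer butyl chain. On these data alone, it is equally open how a chloro or methyl group in place of the nitrile on the aniline ring would pair with either of the two rings.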